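The source may report more compounds than this note shows. Statements on the series, on what has been measured and on what is new or still open speak of the compounds shown alone.

Measured so far in a functional assay on the whole organism (strain Wistar albino) for inhibition, with Rattus norvegicus as the target, read by paw edema, with stated times of 1 h and 2 h, at a dose of 0.32 mmol/kg by the intraperitoneal route; on this read-out higher numbers stand for more inhibition at the one dose given (going by the name of the read-out) and lower numbers for less inhibition:

compound 1 `Cc1ccc(-c2nn(-c3ccc(Cl)cc3)cc2/C=N\c2ccc(Cl)cc2)cc1` gives 48.3%
compound 2 `COc1ccc(-c2nn(-c3ccc(Cl)cc3)cc2/C=N\c2ccc(Cl)cc2)cc1` gives 69.6%
compound 3 `Cc1ccc(-c2nn(-c3ccc(S(N)(=O)=O)cc3)cc2/C=C\C(=O)c2ccc(Cl)cc2)cc1` gives 53.3%

Compounds 1 and 2 share one core and differ at a single place: methoxy in place of methyl on an aromatic carbon. Across this change the read-out in this assay moves by a number 21.3 percentage points higher from compound 1 to compound 2 (beyond the scatter). Going by the values given here, this is the only measured pair in which the change occurs.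

Compound 3 carries a different core; the difference between the two cores is not broken down here. In this assay compound 3 sits closest to compound 1, with the gap between them within the usual scatter, and furthest from compound 2, which stands beyond the scatter above it.

Compound 4 `COc1ccc(-c2nn(-c3ccc(S(N)(=O)=O)cc3)cc2/C=C\C(=O)c2ccc(Cl)cc2)cc1` has not yet been measured. Among the compounds with values here, it is related to compound 3 by methoxy in place of methyl on an aromatic carbon, which is the same change as the one between compounds 1 and 2, in the same kind of place. The change occurs twice in all among these compounds, once measured and once not.

Within the data shown here, the single precedent is the step in this assay from compound 1 to compound 2. Among the measured compounds shown here, with only one example, on a core that is not the core of compound 3, the size of the step from compound 3 to compound 4 is uncertain, but a rise of comparable size is the expectation, resting on a number 21.3 percentage points higher from compound 1 to compound 2 (beyond the scatter). The step from compound 3 to compound 4 is expected to be about a number 16.7 percentage points higher from compound 3 to compound 4 (beyond the scatter). Compound 4 is therefore estimated at 70% in this assay, with a range from 55% to 85%.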

Compound 4, a percentage reported as inhibition, in the whole organism at one dose (the size of the read-out at that dose, not a potency): 55.6%
Estimate against measurement, compound 4: 14.4 percentage points above; low and high end bracket the measured number.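

In this assay, the change from 4-methylphenyl to 4-methoxyphenyl on the core of compound 3 reads as a number 2.3 percentage points higher from compound 3 to compound 4 (within the scatter), so on this core the change cannot be told apart from repeat measurement. The gain seen on the core of compound 1 therefore does not carry over at the same size, and the size of this step depends on the core it is made on: the same change on two cores in this assay, a number 21.3 percentage points higher (beyond the scatter) from compound 1 to compound 2 and a number 2.3 percentage points higher (within the scatter) from compound 3 to compound 4, 19 percentage points apart, beyond the scatter of two such steps This shows only that one result cannot be transferred to the other core at this single dose; with one pair on each core, it gives no rule for other cores, and the cores differ in more than one place, so no part of either core can be picked out as what sets the size of the step.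

The compounds shown leave open how a hydroxyl, an amine or a longer chain such as ethoxy would read in place of methoxy on either core. Going by these compounds alone, they also leave open whether the sulfonamide or the chain joining the rings is tied to the difference between the two steps, since no pair here changes either of these alone.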